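The source may hold more compounds than are shown below. What is called first, only, known or untested is meant among the compounds shown, and "the series" means these compounds.

In a functional assay on SMMC-7721 cells (Homo sapiens) for cytotoxicity, read by MTT assay, with a stated time of 24 h (a higher number here means a weaker inhibitor, a lower number a stronger inhibitor), compound 1 (`CN1C/C(=C\c2ccc(C#N)cc2)C(=O)/C(=C/c2cccnc2)C1`) gives 13600 nM and compound 2 (`CN1C/C(=C\c2ccncc2)C(=O)/C(=C/c2ccccc2F)C1`) gives 7000 nM on the same read-out. Compound 3 (`O=C1/C(=C/c2cccnc2)CN(S(=O)(=O)c2ccccc2)C/C1=C\c1ccccc1F`) gives 19100 nM and so stands within the scatter of compound 1. Its number is higher than that of compound 2 by a gap beyond the scatter, which makes compound 2 the only clear separation among these three values.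

Compound 4 (`O=C1/C(=C/c2cccnc2)CN(S(=O)(=O)c2ccc(Cl)cc2)C/C1=C\c1ccccc1F`) differs from compound 3 by chloro in place of hydrogen on an aromatic carbon on the phenylsulfonyl group, which becomes (4-chlorophenyl)sulfonyl. The change is chloro in place of hydrogen on an aromatic carbon, para to a large group.

Among the compounds with values here, no two measured compounds differ in one place only, so the series offers no direct precedent for the size or direction of this step. The expectation therefore starts from compound 3 at 19100 nM and allows for the modest spread of the three measured values. A step within the scatter is expected in this assay with no firm direction. The estimated step of a 1.3-fold lower number from compound 3 to compound 4 (0.10 log units; within the scatter) is accordingly small. In this assay the expected value for compound 4 is 15000 nM with an estimated range of 7000 nM to 32000 nM around that middle.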

Compound 4, half-maximal inhibitory concentration: 16100 nM
Beside the measured number, compound 4's estimate is 1.1-fold (0.03 log units) below it; measured number inside the range.
By their numbers in this assay, from the lowest: compounds 2, 1, 4 and 3 (each within the scatter of the next, the first and the last beyond it).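

In this assay, within the data shown here, the step of a 1.2-fold lower number from compound 3 to compound 4 (0.07 log units; within the scatter) is the first reading of a change made in one place only, since the earlier compounds differ from one another in more than one place. It shows that chloro in place of hydrogen on an aromatic carbon, para to a large group, turning phenylsulfonyl into (4-chlorophenyl)sulfonyl, gives no separation beyond the scatter in this cytotoxicity read-out. The position therefore carries a chlorine atom with the value staying in the same range as that of the unsubstituted phenylsulfonyl compound, though no data shown here account for this flat step.

Open, as far as these compounds go, is whether a different group at this same place, such as an amine, a carboxylic acid or a methoxy group, would give a step beyond the scatter, as one substituent cannot define the tolerance of the position. Also open, from the compounds shown here alone, is whether chloro in place of hydrogen would read the same on the other aromatic rings of the shared core, as this single pair speaks only for the phenylsulfonyl group.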